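The source may report more compounds than this note shows. Statements on the series, on what has been measured and on what is new or still open speak of the compounds shown alone.

In an ADME assay (liver) for metabolic stability, with Liver microsome (Homo sapiens) as the target, read by LC-MS, using microsomes and NADPH, with a stated time of 5 min, at 37 degrees C (a higher number here means faster removal of the compound, a lower number slower removal), compound 1 `CCn1c([C@@H](C)NS(=O)(=O)c2ccc(C)cc2)nc2ccc(C(F)(F)F)cc21` gives > 100 mL.min-1.g-1, which is a limit of the assay and not a number. Going by the values given here, compound 2 `CCn1c([C@@H](C)NS(=O)(=O)c2ccc(C#N)cc2)nc2ccc(C(F)(F)F)cc21` gives 34 mL.min-1.g-1, the only actual number so far. Compound 3 `CCn1c([C@@H](C)NS(=O)(=O)c2cccc(C#N)c2)nc2ccc(C(F)(F)F)cc21` has the same atoms as compound 2, with 3-cyanophenyl in place of 4-cyanophenyl on a sulfonyl sulfur. Among the compounds with values here, the one measured step, cyano in place of methyl, shows an at least 2.9-fold lower number from compound 1 to compound 2 (0.46 log units; beyond the scatter). That step bears only loosely on this change, since it did not move the nitrile. The expected step is a 1.2-fold higher number from compound 2 to compound 3 (0.07 log units; within the scatter), with no clear direction beyond the scatter. For compound 3, the estimated value is 40 mL.min-1.g-1, within a range of 17 mL.min-1.g-1 to 90 mL.min-1.g-1.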

Compound 3, intrinsic clearance in microsomes: > 100 mL.min-1.g-1
Compound 3 was reported as a limit; the forecaster's own chance of this, stated with the estimate: 10%; at least 2.5-fold (0.39 log units) between middle value and limit.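

Moving the nitrile, with the same atoms kept, clearly matters in this assay: the result is an at least 2.9-fold higher number from compound 2 to compound 3 (0.46 log units; beyond the scatter). The lower number of compound 2 therefore goes with the 4-cyanophenyl group on the sulfonyl sulfur, not with the mere presence of a nitrile. Compound 3 sits at a limit of the assay, not at a number, and the step from compound 1 to compound 3 cannot be read because both compounds stand at that limit: the limit of > 100 mL.min-1.g-1 in this assay, at which 2 of the 3 values shown sit.

Still open, on these data alone, is how far compound 3 lies past its limit. Also open, as far as these compounds go, is how a 4-aminophenyl or 4-carboxyphenyl group on the sulfonyl sulfur would compare with 4-cyanophenyl.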